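Replacing the Benzoxazole on Sulfur with a Methyltetrazole

A few compounds are considered here, and "the series" means these few. Any claim that something is new, unique, unknown or untested is made for them only; others in the source may bear on it.

- Compound 1 `COc1ccc(CN(C(=O)Cn2cc(COc3cc(=O)oc4ccccc34)nn2)c2cc(OC)c(OC)c(OC)c2)cc1`: 5140 nM
- Compound 2 `COc1ccc(CN(C(=O)Cn2cc(COc3ccccc3)nn2)c2cc(OC)c(OC)c(OC)c2)cc1`: 45300 nM
- Compound 3 `COc1ccc(CN(C(=O)Cn2cc(CSc3nc4ccccc4o3)nn2)c2cc(OC)c(OC)c(OC)c2)cc1`: 5050 nM

All three values come from a functional assay on PC-3 cells (Homo sapiens) for antiproliferative activity, read by MTT assay, with a stated time of 48 h; on this read-out higher numbers stand for weaker inhibition and lower numbers for stronger inhibition. Compound 3 has the lowest of the three numbers, but it is level with compound 1, as a 1.0-fold lower number from compound 1 to compound 3 (0.01 log units; within the scatter) shows. Both lie clearly apart from compound 2, as a 9.0-fold lower number from compound 2 to compound 3 (0.95 log units; beyond the scatter) and an 8.8-fold higher number from compound 1 to compound 2 (0.95 log units; beyond the scatter) show.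

Compound 4 `COc1ccc(CN(C(=O)Cn2cc(CSc3nnnn3C)nn2)c2cc(OC)c(OC)c(OC)c2)cc1` is the next to be considered. Its change is 1-methyl-1H-tetrazol-5-yl in place of 1,3-benzoxazol-2-yl on a sulfur. Among the measured compounds shown here, no measured step makes this exact exchange. The closest guide is compound 2, which also ends in a single ring and differs from compound 3 by a 9.0-fold lower number from compound 2 to compound 3 (0.95 log units; beyond the scatter). However, compound 2 has oxygen rather than sulfur, so only part of that step is expected to carry over in this assay. The expected change is a 3.0-fold higher number from compound 3 to compound 4 (0.47 log units; beyond the scatter). Compound 4 is estimated at 15000 nM, with an expected range of 5000 nM to 45000 nM.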

Compound 4, half-maximal inhibitory concentration: 10900 nM
Compound 4: middle estimate off by 1.4-fold (0.14 log units), on the high side; measured number inside the range.
By their numbers in this assay, from the lowest: compounds 3 and 1 (each within the scatter of the next); then compound 4; then compound 2.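

In this assay the exchange on the sulfur gives a 2.2-fold higher number from compound 3 to compound 4 (0.33 log units; beyond the scatter) and so costs only a modest step beyond the scatter, although the entering 1-methyl-1H-tetrazol-5-yl has one ring and 6 heavy atoms where the leaving 1,3-benzoxazol-2-yl has two rings and 9. A single ring at the end of the chain therefore does not by itself bring the number up to that of compound 2, since the change from the phenoxy compound gives a 4.2-fold lower number from compound 2 to compound 4 (0.62 log units; beyond the scatter) in the other direction. The comparison with the two-ring oxygen-linked group agrees with that against the benzoxazole, with a 2.1-fold higher number from compound 1 to compound 4 (0.33 log units; beyond the scatter) as the step.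

From the compounds shown here alone, the step from compound 2 changes the linking atom and the ring together, so the share of the sulfur stays open, and a phenylsulfanyl group on the same chain carbon would separate the two. The data offer no explanation for the size of any of these steps.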